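A few compounds are considered here, and "the series" means these few. Any claim that something is new, unique, unknown or untested is made for them only; others in the source may bear on it.

Measured so far:
- compound 1, `CCCC(Oc1cnn(-c2cccc(Cl)c2)c1)c1ccc(C(=O)NCCC(=O)O)cc1`: 1090 nM
- compound 2, `CCCC(Oc1cnn(-c2ccc(OC)cc2)c1)c1ccc(C(=O)NCCC(=O)O)cc1`: 1980 nM

Compound 2 gives the highest of the two numbers in an assay on isolated protein for displacement of a labelled ligand from Glucagon receptor (Homo sapiens); a higher number here means a weaker inhibitor, a lower number a stronger inhibitor; the nearest is compound 1, a difference recorded as within the scatter (a 1.8-fold higher number from compound 1 to compound 2 (0.26 log units; within the scatter)). Going by the values given here, the single step known so far, from compound 1 to compound 2, swaps the group on the aromatic nitrogen of the shared core and moves the number only a little.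

Compound 3, `CCCC(Oc1cnn(-c2cccc(CC)c2)c1)c1ccc(C(=O)NCCC(=O)O)cc1`, is not yet measured. It differs from compound 2 as follows: 3-ethylphenyl in place of 4-methoxyphenyl on an aromatic nitrogen. Among the compounds with values here, the 3-ethylphenyl that enters carries its substituent on the same ring position as the 3-chlorophenyl of compound 1, so the one step that bears on this change is the one from compound 1 to compound 2, which stayed within the scatter. On that basis no step beyond the scatter is expected in this assay for compound 3, with a slight lean toward the number of compound 1 because 1090 nM belongs to the other ring with a substituent in that position.

Compound 3 is therefore expected at about 1300 nM, within 550 nM to 3100 nM, an estimated step of a 1.5-fold lower number from compound 2 to compound 3 (0.18 log units; within the scatter).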

Compound 3, inhibition constant: 556 nM
Compound 3: the middle estimate sits 2.3-fold (0.37 log units) above what was measured; measured number inside the range.
By their numbers in this assay, from the lowest: compounds 3, 1 and 2 (each within the scatter of the next, the first and the last beyond it).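

In this assay, the change on the aromatic nitrogen now gives a step beyond the scatter, a 3.6-fold lower number from compound 2 to compound 3 (0.55 log units; beyond the scatter), whereas the earlier swap at this place, a 1.8-fold higher number from compound 1 to compound 2 (0.26 log units; within the scatter), did not, so this position can move the number modestly. The two groups exchanged in the new step both count 8 heavy atoms and one six-membered aromatic ring of carbon only, but the 4-methoxyphenyl that leaves has 1 hydrogen-bond acceptor and the 3-ethylphenyl that enters has none. Ethyl in place of chloro on the aromatic carbon stays within the scatter, a 2.0-fold lower number from compound 1 to compound 3 (0.29 log units; within the scatter), so 3-ethylphenyl and 3-chlorophenyl cannot be ranked against each other here, and nothing on hand gives a reason for either step.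

With three compounds, the placing of the substituent on the ring and its identity remain tied together, and 3-methoxyphenyl or 4-ethylphenyl on the same nitrogen would separate the two. As far as these compounds go, whether a longer chain such as propyl or butyl at the ring position held by ethyl goes further than ethyl also remains open.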